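The source may hold more compounds than are shown below. What is called first, only, known or untested is meant among the compounds shown, and "the series" means these compounds.

Compound 2 `Cc1cccc2nc(N3CCN(C)CC3)oc12` gives 0.58 in an assay on ileum (strain Hartley) with 5-hydroxytryptamine receptor 3A (Cavia porcellus) as the target (a lower number here means a smaller maximal response, a higher number a larger maximal response), the second highest of the three numbers seen so far. Compound 3 `Cc1cc(C)c2oc(N3CCN(C)CC3)nc2c1` gives 0.62 in this assay, a difference that lies within the scatter, and compound 1 `Cc1cc(Cl)c2oc(N3CCN(C)CC3)nc2c1` gives 0.26 in this assay. Going by the values given here, compound 4 `CN1CCN(c2nc3cccc(Cl)c3o2)CC1` differs from compound 2 in one place: chloro in place of methyl on an aromatic carbon The one measured step that bears on this exchange runs the other way, a number 0.36 higher from compound 1 to compound 3 (beyond the scatter), and it fell beyond the scatter. Compound 4 is therefore expected to give a lower maximal response than compound 2, with a step of about a number 0.28 lower from compound 2 to compound 4 (beyond the scatter). The estimate for compound 4 is 0.3, expected to fall between 0.15 and 0.5.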

Compound 4, intrinsic activity: the largest response reached, as a fraction of the reference agonist's: 0.24
Compound 4: middle estimate off by 0.060, on the high side, within the range that was stated.
By their numbers in this assay, from the lowest: compounds 4 and 1 (each within the scatter of the next); then compounds 2 and 3 (each within the scatter of the next).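

Chloro in place of methyl on this aromatic carbon, ortho to a fused ring, lowers the maximal response in this assay, a number 0.34 lower from compound 2 to compound 4 (beyond the scatter). The exchange now gives a matching step on two cores: the same change on two cores in this assay, a number 0.36 higher (beyond the scatter) from compound 1 to compound 3 and a number 0.34 higher (beyond the scatter) from compound 4 to compound 2, 0.020 apart, within the scatter of two such steps. Hydrogen in place of methyl at the other substituted aromatic carbon stays within the scatter, a number 0.020 lower from compound 1 to compound 4 (within the scatter), and this too matches across two cores: the same change on two cores in this assay, a number 0.040 higher (within the scatter) from compound 2 to compound 3 and a number 0.020 higher (within the scatter) from compound 4 to compound 1, 0.020 apart, within the scatter of two such steps.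

As far as these compounds go, what hydrogen, fluoro or methoxy would give on the first aromatic carbon remains open. The compounds shown therefore cannot settle whether chloro lowers the response or methyl raises it.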